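The compounds below may be only part of what the source reports. "The series", "measured", "known", "first", "only" and "open" are said of these compounds alone.

Measured so far in a functional assay on HeLa cells (Homo sapiens) for inhibition, read by sulforhodamine B assay; a lower number here means a stronger inhibitor, a higher number a weaker inhibitor:

- Compound 1 `O=C1C(Nc2ccccc2F)=CC(=O)c2c1nc1n2[C@H]2OC[C@@H](O)[C@H]2OC1` gives 9820 nM in this assay.
- Compound 2 `O=C1C=C(Nc2ccc(C(F)(F)F)cc2)C(=O)c2c1nc1n2[C@H]2OC[C@@H](O)[C@H]2OC1` gives > 8000 nM in this assay; that value is a limit of the assay, not a number.

For the measured compounds named here, compound 1 therefore holds the only number known in this assay; the one other value shown sits at the limit of > 8000 nM in this assay, at which 1 of the 2 values shown sits. Both compounds share a core and differ in the group on the amine nitrogen, yet because compound 2 gives only a limit, the pair shows nothing about the size of that change.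

Compound 3 `O=C1C(Nc2cccc(F)c2)=CC(=O)c2c1nc1n2[C@H]2OC[C@@H](O)[C@H]2OC1` is not yet measured. It differs from compound 1 in one place only: 3-fluorophenyl in place of 2-fluorophenyl on an amine nitrogen. The fluorine stays, the ring stays, and only its point of attachment on that ring moves.

Going by the values given here, no step between two measured compounds that differ in one place is available here, so there is no measured step to lean on. With a small change of this kind, the step from compound 1 to compound 3 in this assay is expected to be a 1.2-fold lower number from compound 1 to compound 3 (0.06 log units; within the scatter), that is, no change beyond the usual scatter in either direction. Compound 3 is therefore estimated at 8500 nM in this assay, with a range from 3000 nM to 25000 nM.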

Compound 3, half-maximal inhibitory concentration: > 8000 nM
Compound 3 gave a limit, no number; the forecaster's own chance of this, stated with the estimate: 35%; the middle value lies beyond the limit too.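

In this assay compound 3 gives > 8000 nM, which is a limit of the assay and not a number. The step from compound 1 to compound 3 therefore cannot be read, and the limit now recurs: the limit of > 8000 nM in this assay, at which 2 of the 3 values shown sit.

The compounds shown leave open whether 3-fluorophenyl in place of 2-fluorophenyl changes the result in this assay at all, and by how much.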